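The source may report more compounds than this note shows. Statements on the series, on what has been measured and on what is new or still open speak of the compounds shown alone.

Compound 2 `Cc1ccc(S(=O)(=O)N2CCOCC2)cc1C#Cc1cc(Cl)ccc1OCC(=O)O` holds the lowest of the two numbers recorded in an assay on CHO cells for displacement of a labelled ligand from prostaglandin D2 receptor 2 (Homo sapiens), read by scintillation counting; a lower number here means a stronger inhibitor, a higher number a weaker inhibitor: compound 2 gives 3.6 nM, whereas compound 1 `COC1c2ccc(C#Cc3cc(Cl)ccc3OCC(=O)O)cc2S(=O)(=O)C1(C)C` gives 21 nM, a gap that lies beyond the scatter of repeated measurements. The third member of the set, compound 3 `Cc1ccc(S(=O)(=O)N(C)CCN(C)C)cc1C#Cc1cc(Cl)ccc1OCC(=O)O`, has not yet been measured in this assay. It differs from compound 2 at a single site: (2-(dimethylamino)ethyl)(methyl)amino in place of morpholin-4-yl on a sulfonyl sulfur. For the measured compounds named here, no pair among the measured compounds shows an exchange of this kind, so there is no measured step to lean on, and the outlook rests on the structural change alone. The expectation is a modest step of a 1.7-fold higher number from compound 2 to compound 3 (0.22 log units; within the scatter) toward a somewhat higher number, one that may not clear the usual scatter. Compound 3 is accordingly estimated at 6 nM, with a likely range from 2 nM to 20 nM.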

Compound 3, inhibition constant: 369 nM
Estimate against measurement, compound 3: 62-fold (1.79 log units) below, and the stated range ends below it.
By their numbers in this assay, from the lowest: compound 2; then compound 1; then compound 3.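

In this assay the sulfonyl sulfur proves a sensitive position: replacing morpholin-4-yl with (2-(dimethylamino)ethyl)(methyl)amino gives a 100-fold higher number from compound 2 to compound 3 (2.01 log units; beyond the scatter) and is large enough to show that this single site can govern the reading. The two groups are close in size, at 6 and 7 heavy atoms, yet the ring and its oxygen leave while an open chain with a second nitrogen enters, so similar size alone does not preserve the number here. Nothing measured for these compounds bears on the reason for this rise.

On these data alone, it remains open whether the open chain or its terminal dimethylamino accounts for the step. A piperidin-1-yl, a 4-methylpiperazin-1-yl or a plain dimethylamino group on the sulfonyl sulfur would help separate these two features.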